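The compounds below may be only part of what the source reports. "The series", "measured", "known", "first", "only" and "open" are said of these compounds alone.

Three compounds have been measured in an in vitro assay on UC11MG cells for binding affinity to Substance-P receptor (Homo sapiens), read by radioligand binding; on this read-out higher numbers stand for weaker inhibition and lower numbers for stronger inhibition:

Compound 1, `CN(Cc1cc(C(F)(F)F)cc(C(F)(F)F)c1)C(=O)c1c(CBr)nc2ccccc2c1-c1ccccc1`, gives 52 nM.
Compound 2, `CN(Cc1cc(C(F)(F)F)cc(C(F)(F)F)c1)C(=O)c1c(CO)nc2ccccc2c1-c1ccccc1`, gives 16 nM.
Compound 3, `COCc1nc2ccccc2c(-c2ccccc2)c1C(=O)N(C)Cc1cc(C(F)(F)F)cc(C(F)(F)F)c1`, gives 11 nM.

All three share one core and differ only in the group on the saturated chain carbon bound to an aromatic carbon. Compound 3 has the lowest number of the three, but its gap to compound 2 is within the scatter, as a 1.5-fold lower number from compound 2 to compound 3 (0.16 log units; within the scatter) shows, so the two cannot be ranked; only compound 1 stands apart, with a 4.7-fold lower number from compound 1 to compound 3 (0.67 log units; beyond the scatter) and a 3.3-fold lower number from compound 1 to compound 2 (0.51 log units; beyond the scatter).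

Compound 4, `CN(Cc1cc(C(F)(F)F)cc(C(F)(F)F)c1)C(=O)c1c(CN)nc2ccccc2c1-c1ccccc1`, is not yet measured. It differs from compound 3 in one place: amino in place of methoxy on a saturated chain carbon bound to an aromatic carbon. Among the compounds with values here, no measured step swaps in an amino group, so the only guide is that the two small oxygen-bearing groups at this position gave numbers close together. Compound 4 is therefore expected to stay near compound 3, with the step of a 1.4-fold higher number from compound 3 to compound 4 (0.13 log units; within the scatter) not beyond the scatter. In this assay compound 4 is estimated at 15 nM, within a range of 5 nM to 45 nM.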

Compound 4, half-maximal inhibitory concentration: 9 nM
The estimate for compound 4 lay 1.7-fold (0.22 log units) above the measured number, within the range that was stated.
By their numbers in this assay, from the lowest: compounds 4, 3 and 2 (each within the scatter of the next); then compound 1.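

Amino is the first group at this position that carries no oxygen, and it reads like the two oxygen-bearing groups: a 1.2-fold lower number from compound 3 to compound 4 (0.09 log units; within the scatter), and a 1.8-fold lower number from compound 2 to compound 4 (0.25 log units; within the scatter). The change from methoxy, with 0 hydrogen-bond donors, to amino, with 1, therefore leaves no readable difference on this measurement. Bromo remains the only one of the four groups that stands apart, as a 5.8-fold lower number from compound 1 to compound 4 (0.76 log units; beyond the scatter) shows, and nothing available explains this pattern.

The compounds shown leave open how far this result extends beyond small groups on this saturated chain carbon. A dimethylamino group, a carboxylic acid or a longer chain such as aminoethyl could either stay within the scatter of these compounds or move the number beyond it.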